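Bromo to trifluoromethyl on a shared thioether-linked quinazoline scaffold

A few compounds are considered here, and "the series" means these few. Any claim that something is new, unique, unknown or untested is made for them only; others in the source may bear on it.

In a functional assay on MDA-MB-231 cells (Homo sapiens) for inhibition, read by MTT assay, with a stated time of 72 h (on this read-out lower numbers stand for stronger inhibition and higher numbers for weaker inhibition), the three measured compounds gave the following:
Compound 1, `O=C(CSc1nc(Nc2ccccc2)c2ccccc2n1)Nc1ccc(Br)cc1`: 11500 nM
Compound 2, `O=C(CSc1nc(Nc2ccccc2)c2ccccc2n1)Nc1ccc(C(F)(F)F)cc1`: 11100 nM
Compound 3, `C=CC(=O)Nc1cccc(NC(=O)CSc2nc(Nc3ccc(Br)cc3)c3ccccc3n2)c1`: 17300 nM

Compound 1 and compound 2 differ only by trifluoromethyl in place of bromo on an aromatic carbon, and that change made a 1.0-fold lower number from compound 1 to compound 2 (0.02 log units; within the scatter). Compound 3 carries a different core; how it differs from compound 1 is not broken down here, and its value stands within the scatter of both. Compound 4, `C=CC(=O)Nc1cccc(NC(=O)CSc2nc(Nc3ccc(C(F)(F)F)cc3)c3ccccc3n2)c1`, is not yet measured; it relates to compound 3 by trifluoromethyl in place of bromo on an aromatic carbon, the same change made at the same place. Because the earlier step was a 1.0-fold lower number from compound 1 to compound 2 (0.02 log units; within the scatter), compound 4 is expected to sit close to compound 3, with an estimated step of a 1.0-fold lower number from compound 3 to compound 4 (0.02 log units; within the scatter). The estimate for compound 4 in this assay is 16500 nM, with a likely range from 7000 nM to 38000 nM.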

Compound 4, half-maximal inhibitory concentration: 11500 nM
Estimate against measurement, compound 4: 1.4-fold (0.16 log units) above; the range from low to high includes it.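

In this assay, trifluoromethyl in place of bromo gives a 1.5-fold lower number from compound 3 to compound 4 (0.18 log units; within the scatter). Set beside the earlier case, the two steps do not differ in any readable way: the same change on two cores in this assay, a 1.0-fold lower number (0.02 log units; within the scatter) from compound 1 to compound 2 and a 1.5-fold lower number (0.18 log units; within the scatter) from compound 3 to compound 4, 1.5-fold (0.16 log units) apart, within the scatter of two such steps. So on these two cores the change leaves no difference beyond the scatter, but two pairs in one assay cannot show that this would hold on a further core or in another assay, and neither step says what the group itself contributes.

The compounds shown compare only bromo and trifluoromethyl at this place. On these data alone, how a smaller or very different group, such as an amine, a carboxylic acid or a longer chain, would read there remains open.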